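The source may report more compounds than this note shows. Statements on the series, on what has been measured and on what is new or still open speak of the compounds shown alone.

Measured so far in a functional assay on A549 cells (Homo sapiens) for cytotoxicity, read by MTT assay, with a stated time of 48 h; a higher number here means a weaker inhibitor, a lower number a stronger inhibitor:
compound 1, `COc1cc(C(=O)C2Sc3nnc(-c4cc(OC)c(OC)c(OC)c4)n3NC2c2ccco2)cc(OC)c1OC`: 48300 nM
compound 2, `COc1cc(-c2nnc3n2NC(c2ccco2)C(C(=O)c2ccccc2F)S3)cc(OC)c1OC`: 78700 nM

Compound 1 and compound 2 lie within the scatter of each other, the step being a 1.6-fold higher number from compound 1 to compound 2 (0.21 log units; within the scatter). Compound 3, `COc1cc(-c2nnc3n2NC(c2ccco2)C(C(=O)c2ccc(F)c(F)c2)S3)cc(OC)c1OC`, is not yet measured. It differs from compound 1 by 3,4-difluorophenyl in place of 3,4,5-trimethoxyphenyl on a carbonyl carbon. Within the data shown here, the only step that bears on this is the related swap from compound 1 to compound 2, which stayed within the scatter, so no step beyond the scatter is expected in this assay. Compound 3 is therefore expected to give about 60000 nM, between 25000 nM and 150000 nM. This estimate means an expected step of a 1.2-fold higher number from compound 1 to compound 3 (0.09 log units; within the scatter).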

Compound 3, half-maximal inhibitory concentration: 93700 nM
Compound 3: the middle estimate sits 1.6-fold (0.19 log units) below what was measured, within the range that was stated.
By their numbers in this assay, from the lowest: compounds 1, 2 and 3 (each within the scatter of the next).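

In this assay, 3,4-difluorophenyl on the carbonyl carbon gives a 1.9-fold higher number from compound 1 to compound 3 (0.29 log units; within the scatter), so a second replacement for 3,4,5-trimethoxyphenyl, one with no hydrogen-bond acceptors, also stays within the scatter. The two fluorinated groups cannot be told apart here, with a 1.2-fold higher number from compound 2 to compound 3 (0.08 log units; within the scatter). No outside measurement accounts for these numbers. On these data alone, all three groups at this position are uncharged aromatic rings of carbon only, so it remains open whether an amine or a carboxylic acid on the phenyl ring would produce a step beyond the scatter.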